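A few compounds are considered here, and "the series" means these few. Any claim that something is new, unique, unknown or untested is made for them only; others in the source may bear on it.

Values so far in a functional assay on A-375 cells (Homo sapiens) for inhibition, read by CCK-8 assay, with a stated time of 72 h, tested at 8 uM; on this read-out higher numbers stand for more inhibition of growth at the one concentration tested and lower numbers for less inhibition of growth

Compound 1 `COc1ccc(SCc2ccc(/C=C/C(=O)Nc3ccccc3N)cc2)cc1OC` gives 46.4%
Compound 2 `COc1ccc(SCc2ccc(C(=O)Nc3ccccc3N)cc2)cc1` gives 81.8%
Compound 3 `COc1ccc(SCc2ccc(C(=O)Nc3ccccc3N)cc2)cc1OC` gives 84.6%

On these numbers, compound 2 stands well clear of compound 1. Its nearest neighbour is one measured step away, a number 2.8 percentage points higher from compound 2 to compound 3 (within the scatter), so those two cannot be ranked.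

Compound 4 `Nc1ccccc1NC(=O)c1ccc(CSCCc2ccccc2)cc1` comes from compound 2 by a single change, (phenethyl in place of 4-methoxyphenyl on a sulfur), in short phenethyl in place of 4-methoxyphenyl on a sulfur. For the measured compounds named here, only that same small step bears on this change, since methoxy in place of hydrogen on an aromatic carbon alters the group that leaves here. Going by the values given here, that step keeps the group in place, however, so it says little about swapping the group out entirely, and no measured pair shows such a swap. Differing from compound 3 elsewhere in the structure, compound 1 gives 46.4% and so shows that this family can reach much lower numbers. A moderate fall in this assay is therefore expected, with wide uncertainty. The estimated change is a number 11.8 percentage points lower from compound 2 to compound 4 (beyond the scatter) and its direction is downward. Compound 4 is expected at 70% within an estimated range of 45% to 88% in this measurement.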

Compound 4, percent growth inhibition at one concentration: 69.9%
The estimate for compound 4 lay 0.1 percentage points above the measured number; measured number inside the range.
By their numbers in this assay, from the lowest: compound 1; then compound 4; then compounds 2 and 3 (each within the scatter of the next).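

In this assay, the 4-methoxyphenyl on the sulfur can be replaced outright at a modest cost: a number 11.9 percentage points lower from compound 2 to compound 4 (beyond the scatter), and compound 4 still gives 69.9%. The earlier step, a number 2.8 percentage points higher from compound 2 to compound 3 (within the scatter), only added a methoxy to the ring and kept that ring in place, so it could not show what a full swap of the group does. Here, the entering phenethyl has the same count of heavy atoms and also holds one six-membered aromatic ring of carbon only, but it has no hydrogen-bond acceptor, and no measurement here identifies what lies behind the fall.

The swap changes more than one feature of the group, so the compounds shown leave open whether the fall goes with losing the methoxy or with replacing the aryl group by the phenethyl chain, a question that a plain phenyl or a 4-methoxyphenethyl on the sulfur would help to separate. They also leave open what a group with no aromatic ring, such as a simple alkyl chain or a chain ending in an amine, would do at this place.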